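Changing the amide substituent in a hepatic reductase inhibitor series

This account rests on a few compounds, and the source may have more. Where it says the series, first, only, none or still open, it means among the compounds named here.

Measured compounds:
compound 1, `CC(C)c1c(C(=O)N(C)Cc2ccccc2)nn(-c2ccc(F)cc2)c1CC[C@@H](O)C[C@@H](O)CC(=O)O`, 6.2 nM
compound 2, `CC(C)c1c(C(=O)N2CCCC2c2ccccc2)nn(-c2ccc(F)cc2)c1OC[C@@H](O)C[C@@H](O)CC(=O)O`, 14 nM
compound 3, `CC(C)c1c(C(=O)N2CCC[C@H](N3CCC4C=CC=CC4C3)C2)nn(-c2ccc(F)cc2)c1CC[C@@H](O)C[C@@H](O)CC(=O)O`, 10 nM

All three were tested in an assay on microsomes from liver for inhibition of 3-hydroxy-3-methylglutaryl-coenzyme A reductase (Rattus norvegicus); on this read-out higher numbers stand for weaker inhibition and lower numbers for stronger inhibition. Compound 2 gives the highest number of the three. Its nearest neighbour is compound 3, whose value lies within the usual scatter of compound 2, so no order can be read between these two. Compound 1, with 6.2 nM, sits beyond the scatter from compound 2 and is the lower of that pair. Compound 1 and compound 3 share a carbon-linked side chain, whereas compound 2 carries the ether-linked side chain; no step between two measured compounds differs in only one place, so nothing can be said about the cause of these gaps.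

Compound 4, `COc1cccc(CNC(=O)c2nn(-c3ccc(F)cc3)c(OC[C@@H](O)C[C@@H](O)CC(=O)O)c2C(C)C)c1`, has not yet been measured. It differs from compound 2 by (3-methoxybenzyl)amino in place of 2-phenylpyrrolidin-1-yl on a carbonyl carbon. Like compound 1, it carries a benzylamide, though compound 1 has a methyl on the amide nitrogen and the carbon-linked side chain. On this basis the step of a 1.6-fold lower number from compound 2 to compound 4 (0.19 log units; within the scatter) is expected to be a modest move toward a lower number, perhaps within the scatter. Compound 4 is therefore estimated at 9 nM, with a range from 3.5 nM to 25 nM.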

Compound 4, half-maximal inhibitory concentration: 16 nM
The estimate for compound 4 lay 1.8-fold (0.25 log units) below the measured number; the measured number falls inside the stated range.
By their numbers in this assay, from the lowest: compounds 1, 3, 2 and 4 (each within the scatter of the next, the first and the last beyond it).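

With the ether-linked side chain and the rest of the molecule held constant, replacing 2-phenylpyrrolidin-1-yl with (3-methoxybenzyl)amino gives a 1.1-fold higher number from compound 2 to compound 4 (0.06 log units; within the scatter) in this assay and thus no change that can be read from the numbers. For this one pair, losing the five-membered non-aromatic ring and gaining a hydrogen-bond donor, a hydrogen-bond acceptor and the methoxy oxygen leaves inhibition within the usual scatter, so the two amides cannot be ordered. No measurement shown here offers an explanation for this outcome.

The pair cannot separate the parts of the change, so the separate roles of the methoxy group, the amide hydrogen and the opened ring remain undefined, as would be tested by plain benzylamino, N-methyl-(3-methoxybenzyl)amino or phenethylamino in the same place. As far as these compounds go, it also remains open whether the same exchange would read alike on the carbon-linked side chain, or whether an amine or a carboxylic acid on the benzyl ring would move the number beyond the scatter.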